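A few compounds are considered here, and "the series" means these few. Any claim that something is new, unique, unknown or untested is made for them only; others in the source may bear on it.

Measured compounds:
- Compound 1 `COC(=O)NC12CCC(n3cc(-c4ccc(Cl)c(N)c4)c4c(N)ncnc43)(CC1)CC2`: 23800 ng.h/mL
- Compound 2 `COC(=O)N[C@H]1CC[C@@H](n2cc(-c3ccc(Cl)c(N)c3)c3c(N)ncnc32)CC1`: 17000 ng.h/mL

In an ADME assay on the whole organism (Mus musculus, strain BALB/c) for pharmacokinetics, read by LC-MS, at a dose of 2 mg/kg by the intravenous route (a higher number here means more compound in the circulation at the dose given, a lower number less compound in the circulation), compound 1 gives 23800 ng.h/mL and compound 2 gives 17000 ng.h/mL. Among the measured compounds shown here, these two numbers lie within the usual scatter of each other, so compound 1 stands level with the only other measured compound and neither can be ranked above the other.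

Compound 3 `COC(=O)NC12CCC(n3cc(-c4cc(N)c(Cl)cc4F)c4c(N)ncnc43)(CC1)CC2` keeps the shared core of compound 1 and changes one place on its aromatic ring: fluoro in place of hydrogen on an aromatic carbon. This is fluoro in place of hydrogen on an aromatic carbon, turning 3-amino-4-chlorophenyl into 5-amino-4-chloro-2-fluorophenyl. For the measured compounds named here, no measured pair in this set shows what such a change does in this assay, so the expectation has to start from compound 1 at 23800 ng.h/mL, with no trend to apply to it. The expected step is a 1.2-fold lower number from compound 1 to compound 3 (0.08 log units; within the scatter), which would stay within the scatter. For compound 3 the estimated value is 20000 ng.h/mL, with an expected range of 10000 ng.h/mL to 40000 ng.h/mL.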

Compound 3, area under the concentration-time curve: 18400 ng.h/mL
Beside the measured number, compound 3's estimate is 1.1-fold (0.04 log units) above it, and the stated range covers the measured number.
By their numbers in this assay, from the lowest: compounds 2, 3 and 1 (each within the scatter of the next).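

In this assay, the step for fluoro in place of hydrogen on an aromatic carbon, a 1.3-fold lower number from compound 1 to compound 3 (0.11 log units; within the scatter), lies within the scatter, so compound 3 stands level with compound 1. Among the compounds shown here, this is the first reading for this position, ortho to a large group, meta to a chloro group and para to an amino group: the earlier pair differed elsewhere and gave no step at all, whereas here the change from 3-amino-4-chlorophenyl to 5-amino-4-chloro-2-fluorophenyl can be read directly, and it brings no change that can be told from repeat scatter in the amount of compound in the circulation. The measurements shown offer no explanation for this outcome.

For the compounds shown here, the single fluorine atom shows only that this one small group leaves the number level, so it remains open whether a larger or different group at the same position, such as a methyl, a methoxy, a nitrile or an amine, would do the same. As far as these compounds go, it is also open whether fluoro at this position would read the same way on the core of compound 2, or at another open carbon of the same aromatic ring.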